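Styryl for Chlorophenyl on the Pyrazoline-Type Core

The source may hold more compounds than are shown below. What is called first, only, known or untested is meant among the compounds shown, and "the series" means these compounds.

Compound 1 `Cc1cc(O)c(C2=NN(c3ccc(S(N)(=O)=O)cc3)C(c3ccccc3O)C2)cc1Cl` and compound 2 `Cc1cc(O)c(C2=NN(c3ccc(S(N)(=O)=O)cc3)C(c3ccccc3Cl)C2)cc1Cl` differ by one group. In a functional assay on SK-MEL-2 cells (Homo sapiens) for antiproliferative activity, with a stated time of 48 h (on this read-out higher numbers stand for weaker inhibition of growth and lower numbers for stronger inhibition of growth), compound 1 gives 11000 nM and compound 2 gives 11900 nM; the step of a 1.1-fold higher number from compound 1 to compound 2 (0.03 log units; within the scatter) places compound 2 with the highest number of the two, yet within the scatter of compound 1. Compound 3 `Cc1cc(O)c(C2=NN(c3ccc(S(N)(=O)=O)cc3)C(/C=C/c3ccccc3)C2)cc1Cl` carries 2-phenylethenyl in place of 2-chlorophenyl on a saturated ring carbon. Among the measured compounds shown here, no measured step covers a 2-phenylethenyl group, and the one step known, from hydroxy to chloro, was within the scatter, so in this assay the step of a 1.2-fold lower number from compound 2 to compound 3 (0.08 log units; within the scatter) is expected to stay small. Compound 3 is estimated at 10000 nM, within 4000 nM to 30000 nM.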

Compound 3, concentration for 50% growth inhibition: 16800 nM
For compound 3 the middle estimate is 1.7-fold (0.23 log units) below the measured one, and the stated range covers the measured number.
By their numbers in this assay, from the lowest: compounds 1, 2 and 3 (each within the scatter of the next).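

The saturated ring carbon next to the ring nitrogen now carries 2-phenylethenyl, with its double bond outside aromatic rings, and in this assay the number stays within the scatter of both earlier compounds (a 1.4-fold higher number from compound 2 to compound 3 (0.15 log units; within the scatter); a 1.5-fold higher number from compound 1 to compound 3 (0.18 log units; within the scatter)). The earlier pair showed only a swap of hydroxy for chloro on the same aromatic ring, whereas here a different group at this position also gives no step beyond the scatter. No evidence on hand bears on this result.

From the compounds shown here alone, whether an amine, a carboxylic acid or a longer saturated chain on this carbon would give a step beyond the scatter remains open.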